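A few compounds are considered here, and "the series" means these few. Any claim that something is new, unique, unknown or untested is made for them only; others in the source may bear on it.

Working notes on the series. In an ADME assay on HEK-293T cells (Homo sapiens) for cytotoxicity, read by MTT assay, with a stated time of 3 days (a higher number here means that more compound is tolerated, a lower number that less compound is tolerated), compound 1 (`CC(C)(NC(=O)COC(=O)c1ccc([N+](=O)[O-])o1)c1ccccc1`) gives > 100000 nM, which is a limit of the assay and not a number. Compound 2 (`CC(C)(C)N(Cc1ccc([N+](=O)[O-])cc1)C(=O)COC(=O)c1ccc([N+](=O)[O-])o1`) gives > 100000 nM, likewise a limit and not a number. Both measured compounds share one reading, (the limit of > 100000 nM in this assay, at which 2 of the 2 values shown sit), so compound 2 has no numerical position in the series.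

Compound 3 (`CC(C)(C)N(Cc1ccc(C(F)(F)F)cc1)C(=O)COC(=O)c1ccc([N+](=O)[O-])o1`) keeps the rest of compound 2 and has trifluoromethyl in place of nitro on an aromatic carbon, para to a large group (trifluoromethyl in place of nitro on an aromatic carbon). Among the measured compounds shown here, the series offers no measured step that could size this change. In this assay, no shift beyond the usual scatter is expected, and no direction is favoured. This expectation rests on compound 2, whose reading of > 100000 nM is a limit. The estimated move, a number no higher from compound 2 to compound 3 (the limit leaves the size open), is expected to remain within the scatter. A reading that is again only a limit is considered the most likely outcome. The expected value for compound 3 is 100000 nM, with an estimated range of 40000 nM to 200000 nM.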

Compound 3, half-maximal cytotoxic concentration: 36000 nM
Beside the measured number, compound 3's estimate is 2.8-fold (0.44 log units) above it, outside the stated range (below it).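

In this assay, the series now has its first reading that is a number rather than a limit, and it shows that this position on the six-membered aromatic ring is not silent. Trifluoromethyl in place of nitro on an aromatic carbon, para to a large group, gives an at least 2.7-fold lower number from compound 2 to compound 3 (0.44 log units; beyond the scatter), so less of compound 3 is tolerated, and the change of 4-nitrophenyl to 4-(trifluoromethyl)phenyl is enough on its own to bring the reading into the measurable range. Only a lower bound on the size of this step can be read, since the reading of compound 2 is a limit of the assay and not a number: the limit of > 100000 nM in this assay, at which 2 of the 3 values shown sit.

This single pair gives no trend, and it does not show whether the lower number follows from the arrival of trifluoromethyl or from the loss of nitro. The compounds shown also leave open how an amine, a carboxylic acid, a nitrile or a chlorine atom at the same place would read, and whether the same change would give a similar step on a different amide portion.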